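Replacing the Ring of Compound 3 with a Fluorinated One

The source may hold more compounds than are shown below. What is called first, only, known or untested is meant among the compounds shown, and "the series" means these compounds.

Compound 1 `CN(C)c1ccc(/C=C(/SCc2ccc(F)cc2)C(=O)c2ccc(Br)cc2)cc1`: 50000 nM
Compound 2 `Nc1c(Br)cc(Br)cc1/C=C(\C(=O)c1ccc(Br)cc1)S(=O)(=O)c1ccc(Br)cc1`: 25000 nM
Compound 3 `COc1ccc(/C=C(/SCc2ccc(F)cc2)C(=O)c2ccc(Br)cc2)cc1O`: 1000 nM

All three were measured in a functional assay on DU-145 cells (Homo sapiens) for inhibition, read by trypan blue exclusion, with a stated time of 96 h; a lower number here means a stronger inhibitor of growth, a higher number a weaker inhibitor of growth. Compound 1 gives 50000 nM, compound 2 gives 25000 nM, and compound 3 gives 1000 nM. Compound 3 thus stands lowest of the three numbers, with compound 2 nearest and compound 1 furthest, both gaps beyond the scatter.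

Compound 4 `Cc1cc(F)ccc1/C=C(/SCc1ccc(F)cc1)C(=O)c1ccc(Br)cc1` is not yet measured. It differs from compound 3 by 4-fluoro-2-methylphenyl in place of 3-hydroxy-4-methoxyphenyl on a double-bonded chain carbon bound to a double-bonded chain carbon. Among the measured compounds shown here, one measured step bears on this position: a 50-fold lower number from compound 1 to compound 3 (1.70 log units; beyond the scatter), a large step. For the measured compounds named here, the group entering in compound 4 carries no hydrogen-bond donor or acceptor, unlike the group that leaves, and no other measured pair tests such a ring here. On that single step, compound 4 is expected to give a higher number, a step of a 10-fold higher number from compound 3 to compound 4 (1.00 log units; beyond the scatter) in this assay, beyond the scatter. Compound 4 is estimated at 10000 nM, with a range from 2000 nM to 50000 nM.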

Compound 4, concentration for 50% growth inhibition: 10000 nM
The estimate for compound 4 equals the measured number at the digits printed; measured number inside the range.
By their numbers in this assay, from the lowest: compound 3; then compound 4; then compounds 2 and 1 (each within the scatter of the next).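

In this assay, 4-fluoro-2-methylphenyl in place of 3-hydroxy-4-methoxyphenyl gives a 10-fold higher number from compound 3 to compound 4 (1.00 log units; beyond the scatter), so the advantage of compound 3 at this position is now seen against a second ring and not only against 4-(dimethylamino)phenyl. The same entering group also gives a 5.0-fold lower number from compound 1 to compound 4 (0.70 log units; beyond the scatter), which shows that a ring with 0 hydrogen-bond donors and 0 hydrogen-bond acceptors can still improve on 4-(dimethylamino)phenyl; across compounds 1, 3 and 4, the numbers at this position are graded and do not fall into just two levels. No measurement shown here accounts for either step.

As far as these compounds go, each step changes several ring substituents at once, so the part of 3-hydroxy-4-methoxyphenyl that matters stays open. A phenyl ring carrying only a hydroxyl group or only a methoxy group could separate the two, and a carboxylic acid on the ring remains untested among these compounds.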